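Notes on the aryl substituent series, compound 4

The source may report more compounds than this note shows. Statements on the series, on what has been measured and on what is new or still open speak of the compounds shown alone.

Within the data shown here, compound 3 `O=Cc1ccc(-c2cn3ccnc3c(-c3ccc4ncn(C5CCCCC5)c4c3)n2)cc1` gives 4.21% in a functional assay on SW-620 cells (Homo sapiens) for inhibition, read by sulforhodamine B assay, with a stated time of 48 h, tested at 10 uM (a higher number here means more inhibition at the concentration tested (going by the name of the read-out), a lower number less inhibition), the lowest of the three numbers measured so far. Compound 1 `c1ccc(-c2cn3ccnc3c(-c3ccc4ncn(C5CCCCC5)c4c3)n2)cc1` gives 9.15% and compound 2 `COc1ccc(-c2cn3ccnc3c(-c3ccc4ncn(C5CCCCC5)c4c3)n2)cc1` gives 77.8%. Compound 3 sits nearest compound 1, the two values within the scatter of each other, and furthest from compound 2, that gap being beyond the scatter.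

The unmeasured compound 4 `c1ccc2c(-c3cn4ccnc4c(-c4ccc5ncn(C6CCCCC6)c5c4)n3)cccc2c1` differs from compound 3 in one place: naphthalen-1-yl in place of 4-formylphenyl on an aromatic carbon.

Among the measured compounds shown here, two measured steps bear on this. The step of a number 4.9 percentage points lower from compound 1 to compound 3 (within the scatter) shows that formyl in place of hydrogen on the aromatic carbon moved nothing beyond the scatter, so taking the formyl away again is expected to return roughly to the level of compound 1. The step of a number 73.6 percentage points lower from compound 2 to compound 3 (beyond the scatter) shows that a methoxy at this aromatic carbon gives a large number where formyl gives a small one. For the measured compounds named here, no measured compound carries naphthalen-1-yl at this place, so no step tells how the second fused carbon ring behaves; the expectation rests on compound 1 with 9.15%. Compound 4 is therefore expected to show a step of a number 9.8 percentage points higher from compound 3 to compound 4 (within the scatter), within the scatter. Compound 4 is estimated at 14%, between 0% and 45%, the upper end allowing for the untested second ring.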

Compound 4, a percentage reported as inhibition, at one concentration (the size of the read-out at that concentration, not a potency): 5.34%
Estimate against measurement, compound 4: 8.7 percentage points above, within the range that was stated.
By their numbers in this assay, from the lowest: compounds 3, 4 and 1 (each within the scatter of the next); then compound 2.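

In this assay, naphthalen-1-yl in place of phenyl gives a number 3.8 percentage points lower from compound 1 to compound 4 (within the scatter) and naphthalen-1-yl in place of 4-formylphenyl gives a number 1.1 percentage points higher from compound 3 to compound 4 (within the scatter) at this place, so a second fused carbon ring, like a formyl group, leaves the number at the level of the plain phenyl compound. Naphthalen-1-yl in place of 4-methoxyphenyl gives a number 72.5 percentage points lower from compound 2 to compound 4 (beyond the scatter) in the same assay, which shows that a group with more heavy atoms, made of carbon only, does not reproduce the large number of compound 2. Among the four compounds, compound 2 now stands alone above the other three, and of the groups at this aromatic carbon only 4-methoxyphenyl goes with a large number.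

It remains open whether that number is particular to the methoxy group, since the compounds shown include no hydroxy, ethoxy or dimethylamino group in its stead. No evidence is available on what separates compound 2 from the other three.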